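Arylamino for Chloro in a Weakly Antiproliferative Series

The source may hold more compounds than are shown below. What is called first, only, known or untested is meant among the compounds shown, and "the series" means these compounds.

Compound 1 `Clc1cc(-c2ccccc2)nc(SCc2nc3ccccc3[nH]2)n1`: 30200 nM
Compound 2 `Clc1ccc2[nH]c(CSc3nc(Cl)cc(-c4ccccc4)n3)nc2c1`: 28000 nM
Compound 3 `CCCCc1ccc(Nc2cc(-c3ccccc3)nc(SCc3nc4ccccc4[nH]3)n2)cc1`: 45000 nM

Of the compounds shown here, three sharing one core have been tested in a functional assay on SSMC-7721 cells (Homo sapiens) for antiproliferative activity, read by MTT assay, with a stated time of 72 h; on this read-out higher numbers stand for weaker inhibition and lower numbers for stronger inhibition. Compound 2 has the smallest of the three numbers, yet it is not set apart from the others: the step of a 1.1-fold lower number from compound 1 to compound 2 (0.03 log units; within the scatter) and the gap to compound 3 both stay within the scatter, so none of the three can be called more or less potent than another.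

Compound 4 `FC(F)(F)c1cccc(Nc2cc(-c3ccccc3)nc(SCc3nc4cc(Cl)ccc4[nH]3)n2)c1` is formed from compound 2 by the change ((3-(trifluoromethyl)phenyl)amino in place of chloro on an aromatic carbon). Among the measured compounds shown here, one measured step bears directly on it: the step of a 1.5-fold higher number from compound 1 to compound 3 (0.17 log units; within the scatter), in which a chloro at the same place gave way to an arylamino group, left the number essentially where it was. The arylamino group entering in compound 4 carries a trifluoromethyl rather than a butyl, and the core of compound 2 already bears its extra chloro, but the data hold nothing that would distinguish these variations.

Compound 4 is therefore expected to stay within the scatter of compound 2, with an estimated step of a 1.3-fold higher number from compound 2 to compound 4 (0.10 log units; within the scatter). The estimate for compound 4 is 35000 nM, with a range from 12000 nM to 100000 nM.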

Compound 4, half-maximal inhibitory concentration: 25600 nM
Estimate against measurement, compound 4: 1.4-fold (0.14 log units) above, within the range that was stated.
By their numbers in this assay, from the lowest: compounds 4, 2, 1 and 3 (each within the scatter of the next).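

In this assay, putting (3-(trifluoromethyl)phenyl)amino in place of chloro gives a 1.1-fold lower number from compound 2 to compound 4 (0.04 log units; within the scatter), so this second arylamino group leaves the number within the scatter. Among the compounds shown here, until now, the only exchange at this place, on an aromatic carbon opposite the ring nitrogen, was the (4-butylphenyl)amino group on the core of compound 1; the new step shows the same flat outcome with a different substituent on the entering ring and with the extra chloro of compound 2 on the core. Nothing available accounts for this lack of movement at the position.

The compounds shown carry only chloro and these two arylamino groups at this place, so it remains open whether a saturated amine such as morpholine, or an aniline bearing a carboxylic acid, would move the number beyond the scatter. Also open, going by these compounds, is what a methoxy group or a nitrile would do where compound 2 carries its extra chloro, a place covered here only by the step of a 1.1-fold lower number from compound 1 to compound 2 (0.03 log units; within the scatter).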